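What a Methoxy Group Might Do to Compound 1

This account rests on a few compounds, and the source may have more. Where it says the series, first, only, none or still open, it means among the compounds named here.

In a functional assay on NCI-H460 cells (Homo sapiens) for inhibition, read by MTT assay, with a stated time of 24 h, tested at 0.1 ug/mL (a lower number here means less inhibition of growth, a higher number more inhibition of growth at the concentration tested), compound 1 `O=C(CCCCC(S)CCS)Nc1ccccc1` gives 5.5%. Two close relatives have been measured alongside it: compound 2 `O=C(CCCCC(S)CCS)Nc1ccccc1Cl` gives 6.36%, and compound 3 `O=C(CCCCC(S)CCS)Nc1cccc(C(F)(F)F)c1` gives 12%. Compound 1 cannot be told apart from either of them, given the usual scatter of such measurements.

The unmeasured compound 4 `COc1ccc(NC(=O)CCCCC(S)CCS)cc1` keeps the core of compound 1 and changes one place: methoxy in place of hydrogen on an aromatic carbon. This is methoxy in place of hydrogen on an aromatic carbon, para to a large group.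

Among the compounds with values here, two measured steps bear on this change, since each of them also alters compound 1 at a single place. With chloro the result is a number 0.9 percentage points higher from compound 1 to compound 2 (within the scatter), and with trifluoromethyl it is a number 6.5 percentage points higher from compound 1 to compound 3 (within the scatter). Neither step leaves the scatter, so none beyond the scatter is expected here in this assay. Within the data shown here, no measured compound carries a methoxy group, which leaves the estimate uncertain. The expected step is a number 2.5 percentage points higher from compound 1 to compound 4 (within the scatter), small and with no firm direction. The estimated value for compound 4 is 8%, with an expected range from 2% to 18%.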

Compound 4, percent growth inhibition at one concentration: 5.69%
For compound 4 the middle estimate is 2.3 percentage points above the measured one; measured number inside the range.
By their numbers in this assay, from the lowest: compounds 1, 4, 2 and 3 (each within the scatter of the next).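

In this assay, methoxy on an aromatic carbon, para to a large group, gives a number 0.2 percentage points higher from compound 1 to compound 4 (within the scatter). Within the data shown here, neither the chloro of compound 2 nor the trifluoromethyl of compound 3 sits para to a large group, so this is the first reading at that place on the ring, and it shows that a group joined through oxygen can stand there without moving the number out of the scatter around compound 1. Nothing available explains why this step is so small or shows what the methoxy group does in these cells.

The compounds shown leave open whether an amine or a carboxylic acid at this same place would give a step beyond the scatter, or whether a longer chain on the oxygen, such as ethoxy, would stay as close to compound 1. From the compounds shown here alone, it is also open how chloro or trifluoromethyl would read at this place, since a comparison of groups on the ring is only clean when they sit on the same carbon.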